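Benzyl Variation on a Triazolopyrimidine Cytotoxicity Series

The source may hold more compounds than are shown below. What is called first, only, known or untested is meant among the compounds shown, and "the series" means these compounds.

Compound 2 `Cc1cc(Nc2ccn(Cc3ccc(C(F)(F)F)cc3)n2)n2nc(SCc3ccc(Br)cc3)nc2n1` gives 30200 nM in an ADME assay on GES1 cells (Homo sapiens) for inhibition, read by MTT assay, with a stated time of 72 h (a lower number here means a stronger inhibitor, a higher number a weaker inhibitor), the highest of the two numbers seen, with compound 1 `Cc1cc(Nc2ccn(Cc3cccc4ccccc34)n2)n2nc(SCc3ccc(Br)cc3)nc2n1` at 30000 nM as its nearest neighbour. Within the data shown here, the one step measured so far, a 1.0-fold higher number from compound 1 to compound 2 (0.00 log units; within the scatter), changed the same benzyl position without effect. Compound 3 `Cc1cc(Nc2ccn(Cc3ccccc3)n2)n2nc(SCc3ccc(Br)cc3)nc2n1` differs from compound 2 by hydrogen in place of trifluoromethyl on an aromatic carbon. Since the comparable change left this assay flat, the step is expected to fall within the scatter, so a 1.0-fold lower number from compound 2 to compound 3 (0.00 log units; within the scatter) is estimated. Compound 3 is therefore expected to give about 30000 nM, within 15000 nM to 60000 nM.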

Compound 3, half-maximal inhibitory concentration: 44400 nM
For compound 3 the middle estimate is 1.5-fold (0.17 log units) below the measured one; the measured number falls inside the stated range.
By their numbers in this assay, from the lowest: compounds 1, 2 and 3 (each within the scatter of the next).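

In this assay, the plain benzyl group extends the set at this position: hydrogen in place of trifluoromethyl gives a 1.5-fold higher number from compound 2 to compound 3 (0.17 log units; within the scatter), and phenyl in place of naphthalen-1-yl gives a 1.5-fold higher number from compound 1 to compound 3 (0.17 log units; within the scatter). Compounds 1, 2 and 3 thus stay within the scatter of one another, so neither removing the trifluoromethyl nor replacing the naphthalen-1-yl separates them. No supporting measurement bears on this result. Still open, from the compounds shown here alone, is whether an amine or a carboxylic acid on this ring would move the number. A longer chain linking the ring to the shared core also remains an open question.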